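Compound 2 to compound 3: a new ring on the chain

This account rests on a few compounds, and the source may have more. Where it says the series, first, only, none or still open, it means among the compounds named here.

Compound 1 `COC(=O)C1=C(CN2CCCCC2)NC(c2nccs2)=NC1(C)c1ccc(F)cc1` gives 88 mL/min/kg
Compound 2 `COC(=O)C1=C(CN2CCC(F)(F)CC2)NC(c2nccs2)=NC1(C)c1ccc(F)cc1` gives 88 mL/min/kg

Both were tested in an ADME assay on microsomes from liver (Mus musculus) for metabolic stability, read by LC-MS, using NADPH, with stated times of 10 min and 30 min, tested at 1 uM (a higher number here means faster removal of the compound, a lower number slower removal), and compound 1 stands level with compound 2 at 88 mL/min/kg on this measure. Compound 3 `COC(=O)C1=C(CN2CCC(O)C2)NC(c2nccs2)=NC1(C)c1ccc(F)cc1` carries 3-hydroxypyrrolidin-1-yl in place of 4,4-difluoropiperidin-1-yl on a saturated chain carbon bound to a double-bonded ring carbon. Going by the values given here, the one measured step at this place is no change at the digits printed from compound 1 to compound 2 (within the scatter), which lies within the scatter, and no measured compound holds the entering group. A modest downward move is expected in this assay, with a 1.3-fold lower number from compound 2 to compound 3 (0.10 log units; within the scatter) as the estimated step. Compound 3 is estimated at 70 mL/min/kg with 40 mL/min/kg to 100 mL/min/kg as its expected range.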

Compound 3, clearance: 83 mL/min/kg
Compound 3: the middle estimate sits 1.2-fold (0.07 log units) below what was measured, and the stated range covers the measured number.
By their numbers in this assay, from the lowest: compounds 3, 1 and 2 (each within the scatter of the next).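

In this assay, moving to 3-hydroxypyrrolidin-1-yl, a five-membered ring with a hydrogen-bond donor, gives a 1.1-fold lower number from compound 2 to compound 3 (0.03 log units; within the scatter) and, measured against the unsubstituted piperidin-1-yl, a 1.1-fold lower number from compound 1 to compound 3 (0.03 log units; within the scatter). Across these three compounds, then, neither the ring size nor the swap of fluorine for hydroxyl at this place separates the readings beyond the scatter. No evidence is available on why the readings sit together. Going by these compounds, whether a morpholin-4-yl or an open-chain dimethylamino group on the same chain carbon would read differently stays open. So does whether a carboxylic acid there would separate from these three.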